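Notes on the step from compound 3 to compound 4

This account rests on a few compounds, and the source may have more. Where it says the series, first, only, none or still open, it means among the compounds named here.

Among the measured compounds shown here, compound 3 `O=C(NC[C@@H]1CCCc2cc(S(=O)(=O)c3cccc(F)c3)ccc21)[C@H]1CCCN1` gives 0.631 nM in an assay on isolated protein for displacement of a labelled ligand from 5-hydroxytryptamine receptor 6 (Homo sapiens) (on this read-out lower numbers stand for stronger inhibition and higher numbers for weaker inhibition), the second highest of the three numbers measured so far. Compound 1 `CN(C)S(=O)(=O)NC[C@@H]1CCCc2cc(S(=O)(=O)c3cccc(F)c3)ccc21` gives 2 nM in this assay, and a 3.2-fold lower number from compound 1 to compound 3 (0.50 log units; beyond the scatter). Compound 2 `O=C1CN=C(NC[C@@H]2CCCc3cc(S(=O)(=O)c4cccc(F)c4)ccc32)N1` gives 0.1 nM in this assay, and a 6.3-fold higher number from compound 2 to compound 3 (0.80 log units; beyond the scatter). The largest step recorded is a 20-fold lower number from compound 1 to compound 2 (1.30 log units; beyond the scatter). All three steps exchange the group carried on the amine nitrogen while the nitrogen and its hydrogen remain.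

Compound 4 `O=C1CN(C[C@@H]2CCCc3cc(S(=O)(=O)c4cccc(F)c4)ccc32)CCN1` is not yet measured. It differs from compound 3 by 3-oxopiperazin-1-yl in place of ((pyrrolidin-2-yl)carbonyl)amino on a saturated chain carbon bound to a saturated ring carbon. For the measured compounds named here, none of the measured steps removes the hydrogen on that nitrogen or turns the attachment into a ring nitrogen, so they bear on this step only loosely: they show that changes in this place shift this assay by modest to large amounts in either direction. Given that compound 3 gives 0.631 nM, a modest rise is expected, a 3.2-fold higher number from compound 3 to compound 4 (0.50 log units; beyond the scatter). For compound 4 the estimate in this assay is 2 nM, with a range from 0.5 nM to 8 nM.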

Compound 4, inhibition constant: 6.31 nM
Beside the measured number, compound 4's estimate is 3.2-fold (0.50 log units) below it; measured number inside the range.
By their numbers in this assay, from the lowest: compound 2; then compound 3; then compound 1; then compound 4.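

Among the compounds shown, only compound 4 carries its group through a ring nitrogen with no hydrogen on it, and in this assay this change gives a 10-fold higher number from compound 3 to compound 4 (1.00 log units; beyond the scatter). The same comparison with the other two gives a 63-fold higher number from compound 2 to compound 4 (1.80 log units; beyond the scatter) and a 3.2-fold higher number from compound 1 to compound 4 (0.50 log units; beyond the scatter), so compound 4 has the highest number of the four and every step to the 3-oxopiperazin-1-yl group goes upward. This single change cannot separate the loss of that hydrogen from the loss of the pyrrolidin-2-yl ring or the new six-membered ring.

No measurement here speaks to the origin of this rise. From the compounds shown here alone, it remains open whether a methyl group on the amine nitrogen of compound 3, or a piperazine lacking the carbonyl, would move the number in this assay the same way.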